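Replacing pyridin-4-yl with 3-hydroxyphenyl on a shared core

The compounds below may be only part of what the source reports. "The series", "measured", "known", "first", "only" and "open" are said of these compounds alone.

In a functional assay on MDA-MB-231 cells (Homo sapiens) for cytotoxicity, read by ELISA, with a stated time of 2 days (on this read-out lower numbers stand for stronger inhibition and higher numbers for weaker inhibition), compound 1 `Oc1cccc(-c2cc(-c3ccccc3)cc(-c3cccs3)n2)c1` gives 18100 nM and compound 2 `Oc1cccc(-c2cc(-c3ccccc3)cc(-c3ccncc3)n2)c1` gives 10400 nM. Within the data shown here, these are the only two measured values, and they lie within the scatter of each other, so compound 2 stands level with compound 1.

Compound 3 `Oc1cccc(-c2cc(-c3ccccc3)cc(-c3cccc(O)c3)n2)c1` keeps the core of compound 2 but changes the group on an aromatic carbon next to the ring nitrogen, with 3-hydroxyphenyl in place of pyridin-4-yl on an aromatic carbon. Among the measured compounds shown here, the only measured step at this place is the exchange of thiophen-2-yl for pyridin-4-yl, a 1.7-fold lower number from compound 1 to compound 2 (0.24 log units; within the scatter). For the measured compounds named here, that single step is small, but it is a thin guide, since no measured compound carries 3-hydroxyphenyl at this place. On the strength of that step, no change beyond the scatter is expected in this assay, and the estimated step is a 1.2-fold lower number from compound 2 to compound 3 (0.06 log units; within the scatter). The range is left wide to allow for the untested group. In this assay, compound 3 is expected at 9000 nM, with an estimated range from 3000 nM to 27000 nM.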

Compound 3, half-maximal inhibitory concentration: 12800 nM
The estimate for compound 3 lay 1.4-fold (0.15 log units) below the measured number, within the range that was stated.
By their numbers in this assay, from the lowest: compounds 2, 3 and 1 (each within the scatter of the next).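

In this assay, 3-hydroxyphenyl at this place gives a 1.2-fold higher number from compound 2 to compound 3 (0.09 log units; within the scatter) and a 1.4-fold lower number from compound 1 to compound 3 (0.15 log units; within the scatter). With this third group, the comparison now spans thiophen-2-yl, pyridin-4-yl and 3-hydroxyphenyl, and all three stand level in this assay, even though 3-hydroxyphenyl brings a hydrogen-bond donor that pyridin-4-yl lacks and a ring of carbon only in place of a ring with a hetero atom. Neither that donor nor the loss of the ring nitrogen of pyridin-4-yl goes with a difference beyond the scatter here, and no measurement at hand offers an explanation for these compounds standing level.

From the compounds shown here alone, all three groups at this place are aromatic rings, so it stays open whether an amine, a carboxylic acid or a longer alkyl chain there would also stand level with them. Going by these compounds, the 3-hydroxyphenyl and phenyl groups elsewhere on the shared core are the same in all three compounds, so what either contributes to the numbers in this assay also stays open.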